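The compounds below may be only part of what the source reports. "The series", "measured", "known", "first", "only" and "open" are said of these compounds alone.

Measured so far:
Compound 1 `O=C1/C(=C\c2ccc(F)cc2)c2ccccc2N1c1c(Cl)cccc1Cl` gives 13 ug/mL in a functional assay on L132 cells (Homo sapiens) for cytotoxicity, read by MTT assay, with a stated time of 72 h; on this read-out lower numbers stand for an effect already at smaller amounts and higher numbers for an effect only at larger amounts of compound.
Compound 2 `O=C1/C(=C\c2ccccc2[N+](=O)[O-])c2ccccc2N1c1c(Cl)cccc1Cl` gives 10 ug/mL in this assay.

Both compounds share the same core and differ only in the ring hanging from the double-bonded chain carbon. Compound 2 stands with compound 1 on essentially the same level: the step of a 1.3-fold lower number from compound 1 to compound 2 (0.11 log units; within the scatter) lies within the scatter, so the two numbers cannot be told apart.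

Compound 3 `O=C1/C(=C\c2ccccc2Cl)c2ccccc2N1c1c(Cl)cccc1Cl` has not yet been measured. It differs from compound 2 by chloro in place of nitro on an aromatic carbon. For the measured compounds named here, the only measured step that bears on this is the one from compound 1 to compound 2, which also swapped the group on that same ring and stayed within the scatter. The change to compound 3 is therefore expected to give no step beyond the scatter, a 1.1-fold higher number from compound 2 to compound 3 (0.04 log units; within the scatter). Compound 3 is estimated at 11 ug/mL, with a range from 5 ug/mL to 25 ug/mL.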

Compound 3, concentration for half-maximal effect: > 100 ug/mL
Compound 3: no number, only a limit; the forecaster's own chance of this, stated with the estimate: 5%; middle value at least 9.0-fold (0.95 log units) away from the limit.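

So far, the ring on the double-bonded chain carbon had looked tolerant of change, yet the numbers in this assay now show that it is not. Chloro in place of nitro, on the aromatic carbon ortho to a large group, gives an at least 10-fold higher number from compound 2 to compound 3 (1.00 log units; beyond the scatter), and 2-chlorophenyl in place of 4-fluorophenyl gives an at least 7.6-fold higher number from compound 1 to compound 3 (0.88 log units; beyond the scatter), so one small exchange on this ring can move the read-out well beyond the scatter. Both steps are minimum sizes, as compound 3 has only a limit of the assay and no exact number: the limit of > 100 ug/mL in this assay, at which 1 of the 3 values shown sits.

On these data alone, how far compound 3 really lies from compound 1 and compound 2 remains open. Also open, as far as these compounds go, is whether an amine or a methoxy group at this same place would give a number like that of compound 2 or a limit like that of compound 3.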